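Swapping the Anilide Substituent: Methoxy Out, Bromine In

The compounds below may be only part of what the source reports. "The series", "measured", "known", "first", "only" and "open" are said of these compounds alone.

In an assay on isolated protein for inhibition of glutathione S-transferase P (Homo sapiens), with a stated time of 10 min (a higher number here means a weaker inhibitor, a lower number a stronger inhibitor), compound 3 `COc1ccccc1NC(=O)CCC(=O)OCCCCCCSc1ccc([N+](=O)[O-])c2nonc12` gives 4050 nM, the second highest of the three numbers shown. Compound 1 `O=C(O)CCC(=O)OCCCCCCSc1ccc([N+](=O)[O-])c2nonc12` gives 530 nM, and compound 2 `O=C(CCC(=O)OCCCCCCSc1ccc([N+](=O)[O-])c2nonc12)Nc1ccccc1Cl` gives 15500 nM. The change now considered is 4-bromophenyl in place of 2-methoxyphenyl on an amide-type nitrogen, giving compound 4 `O=C(CCC(=O)OCCCCCCSc1ccc([N+](=O)[O-])c2nonc12)Nc1ccc(Br)cc1`. The relevant measured steps are a 7.6-fold higher number from compound 1 to compound 3 (0.88 log units; beyond the scatter) and a 29-fold higher number from compound 1 to compound 2 (1.47 log units; beyond the scatter), while within the anilides a 3.8-fold lower number from compound 2 to compound 3 (0.58 log units; beyond the scatter). Compound 4 is expected to sit closer to compound 2 than to compound 3 because compound 2 gives 15500 nM with its own halogen-bearing anilide. The expected step is therefore a 2.0-fold higher number from compound 3 to compound 4 (0.30 log units; within the scatter), toward weaker inhibition. Compound 4 is estimated at 8000 nM, ranging from 3000 nM to 25000 nM.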

Compound 4, half-maximal inhibitory concentration: 5090 nM
The estimate for compound 4 lay 1.6-fold (0.20 log units) above the measured number, and the stated range covers the measured number.
By their numbers in this assay, from the lowest: compound 1; then compounds 3 and 4 (each within the scatter of the next); then compound 2.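

On the amide-type nitrogen, 4-bromophenyl and 2-methoxyphenyl cannot be told apart in this assay with a 1.3-fold higher number from compound 3 to compound 4 (0.10 log units; within the scatter) as the step. A halogen-bearing anilide therefore need not read like compound 2, since the step is a 3.0-fold lower number from compound 2 to compound 4 (0.48 log units; beyond the scatter) between the two halogen-bearing anilides. Even so, (4-bromophenyl)amino does not match hydroxy on the carbonyl carbon, at a 9.6-fold higher number from compound 1 to compound 4 (0.98 log units; beyond the scatter) for that exchange.

Nothing available explains these differences. From the compounds shown here alone, whether the gap follows the halogen or its ring position stays open, and 4-chlorophenyl or 2-bromophenyl would be needed to separate the two.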